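From thiophen-2-yl to 1,3-thiazol-2-yl: working notes on compound 3

The source may hold more compounds than are shown below. What is called first, only, known or untested is meant among the compounds shown, and "the series" means these compounds.

Measured in a functional assay on HUVEC cells (Homo sapiens) for cytotoxicity; on this read-out higher numbers stand for an effect only at larger amounts of compound and lower numbers for an effect already at smaller amounts:
- compound 1 `COC1=C(C)C(=O)/C(=C(O)/C=C/c2ccco2)C(=O)C1(C)C`: 2.4 ug/mL
- compound 2 `COC1=C(C)C(=O)/C(=C(O)/C=C/c2cccs2)C(=O)C1(C)C`: 2.5 ug/mL

Compound 2 gives 2.5 ug/mL, level with compound 1 within the scatter. Compound 3 `COC1=C(C)C(=O)/C(=C(O)/C=C/c2nccs2)C(=O)C1(C)C` carries 1,3-thiazol-2-yl in place of thiophen-2-yl on a double-bonded chain carbon bound to a double-bonded chain carbon. For the measured compounds named here, only one measured step bears on this change, a ring exchange at the same place: a 1.0-fold higher number from compound 1 to compound 2 (0.02 log units; within the scatter). That single step is thin evidence, but no step beyond the scatter is expected in this assay. The expected step is a 1.0-fold higher number from compound 2 to compound 3 (0.02 log units; within the scatter). Compound 3 is estimated at 2.6 ug/mL, with an expected range from 1.3 ug/mL to 5.5 ug/mL.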

Compound 3, concentration for half-maximal effect: 1.6 ug/mL
The estimate for compound 3 lay 1.6-fold (0.21 log units) above the measured number, and the stated range covers the measured number.
By their numbers in this assay, from the lowest: compounds 3, 1 and 2 (each within the scatter of the next).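

Swapping in a ring nitrogen at this place moves the number only a 1.6-fold lower number from compound 2 to compound 3 (0.19 log units; within the scatter) in this assay, and a 1.5-fold lower number from compound 1 to compound 3 (0.18 log units; within the scatter) is of the same kind, so neither step lies beyond the scatter. Thus furan-2-yl, thiophen-2-yl and 1,3-thiazol-2-yl, on a double-bonded chain carbon bound to a double-bonded chain carbon, all read alike within the scatter. No measurement is at hand that would explain these numbers.

Open, as far as these compounds go, is whether a pyridin-2-yl ring or a chain ending in an amine at this place would give a step beyond the scatter in this assay.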